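This account rests on a few compounds, and the source may have more. Where it says the series, first, only, none or still open, it means among the compounds named here.

Measured so far in a functional assay on A549 cells (Homo sapiens) for antiproliferative activity, read by MTT assay; on this read-out higher numbers stand for weaker inhibition and lower numbers for stronger inhibition:
- compound 1 `COC(=O)N1CCCc2cc(S(=O)(=O)N3CC(c4ccccc4)NC3=O)ccc21`: 1150 nM
- compound 2 `CCOC(=O)N1CCCc2cc(S(=O)(=O)N3CC(c4ccccc4)NC3=O)ccc21`: 344 nM
- compound 3 `O=C(OCCCl)N1CCCc2cc(S(=O)(=O)N3CC(c4ccccc4)NC3=O)ccc21`: > 20000 nM, a limit of the assay and not a number

Compound 3 has no number in this assay and stands only at the limit: the limit of > 20000 nM in this assay, at which 1 of the 3 values shown sits.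

The next step leads to compound 4 `NC(=O)N1CCCc2cc(S(=O)(=O)N3CC(c4ccccc4)NC3=O)ccc21`, with amino in place of 2-chloroethoxy on a carbonyl carbon.

Going by the values given here, three measured steps bear on this change, all made in the group on that same carbonyl carbon. One is modest: a 3.3-fold lower number from compound 1 to compound 2 (0.52 log units; beyond the scatter). Two are large: an at least 17-fold higher number from compound 1 to compound 3 (1.24 log units; beyond the scatter) and an at least 58-fold higher number from compound 2 to compound 3 (1.76 log units; beyond the scatter). Among these three compounds, only compound 3 carries the chloro group, and that group leaves in the new step. Among the compounds with values here, no measured compound has amino at this place, so the size of the step is poorly fixed. A large step towards a lower number is nevertheless expected in this assay, resting on the size of an at least 58-fold higher number from compound 2 to compound 3 (1.76 log units; beyond the scatter). The expected change is an at least 8.0-fold lower number from compound 3 to compound 4 (0.90 log units; beyond the scatter).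

The estimate for compound 4 is 2500 nM, with an expected range of 400 nM to 15000 nM.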

Compound 4, half-maximal inhibitory concentration: 2540 nM
Beside the measured number, compound 4's estimate is 1.0-fold (0.01 log units) below it; measured number inside the range.
By their numbers in this assay, from the lowest: compound 2; then compound 1; then compound 4. At a limit, above all of these: compound 3.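

In this assay, amino on this carbonyl carbon ranks behind both simple alkoxy groups: a 7.4-fold higher number from compound 2 to compound 4 (0.87 log units; beyond the scatter), and a 2.2-fold higher number from compound 1 to compound 4 (0.34 log units; beyond the scatter). Set against 2-chloroethoxy, amino returns a measurable value, an at least 7.8-fold lower number from compound 3 to compound 4 (0.89 log units; beyond the scatter), so the order at this place now runs ethoxy, methoxy, amino, and among the four groups shown only 2-chloroethoxy falls out of the measurable range. Compound 3 remains a limit of the assay and not a number, so the step from it is a bound only: the limit of > 20000 nM in this assay, at which 1 of the 4 values shown sits.

The compounds shown leave open whether a longer chain such as propoxy or butoxy would continue the gain seen from methoxy to ethoxy, and whether fluoro on the ethoxy chain would bring the same loss as chloro. They also leave open whether methylamino or dimethylamino on this carbonyl carbon would stay close to amino or move towards the ethoxy group, and whether any of these changes would hold on other cell lines.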